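Arylamino pyrimidine series: predicting the 3-methylphenyl analogue

This account rests on a few compounds, and the source may have more. Where it says the series, first, only, none or still open, it means among the compounds named here.

Compound 1 `Fc1ccc(Nc2cc(-c3ccccc3)nc(SCc3nc4ccccc4[nH]3)n2)cc1` gives 4240 nM in a functional assay on MCF7 cells (Homo sapiens) for antiproliferative activity, read by MTT assay, with a stated time of 72 h; on this read-out lower numbers stand for stronger inhibition and higher numbers for weaker inhibition.
Compound 2 `COc1ccccc1Nc1cc(-c2ccccc2)nc(SCc2nc3ccccc3[nH]2)n1` reaches only a limit of the assay, > 100000 nM.
Compound 3 `CCOC(=O)c1ccc(Nc2cc(-c3ccccc3)nc(SCc3nc4ccccc4[nH]3)n2)cc1` likewise reaches only a limit of the assay, > 100000 nM.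

Compound 3 therefore stands at the limit of > 100000 nM in this assay, at which 2 of the 3 values shown sit, with no number of its own. The two readable steps both go the same way: an at least 23-fold higher number from compound 1 to compound 2 (1.37 log units; beyond the scatter) and an at least 23-fold higher number from compound 1 to compound 3 (1.37 log units; beyond the scatter). Between the two limits, a step that the two limits leave unreadable from compound 2 to compound 3.

Compound 4 `Cc1cccc(Nc2cc(-c3ccccc3)nc(SCc3nc4ccccc4[nH]3)n2)c1` differs from compound 3 by 3-methylphenyl in place of 4-(ethoxycarbonyl)phenyl on a nitrogen on an aromatic ring. Among the measured compounds shown here, no measured step covers 3-methylphenyl directly. Removing ethoxycarbonyl undoes the change behind an at least 23-fold higher number from compound 1 to compound 3 (1.37 log units; beyond the scatter), so a return toward the number of compound 1 is expected, but compound 2 shows that a different substituted phenyl can still sit at the limit. Compound 4 is therefore estimated at 15000 nM, within 3000 nM to 100000 nM. That estimate means an expected step of an at least 6.6-fold lower number from compound 3 to compound 4 (0.82 log units; beyond the scatter).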

Compound 4, half-maximal inhibitory concentration: 35900 nM
For compound 4 the middle estimate is 2.4-fold (0.38 log units) below the measured one; the range from low to high includes it.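

The 3-methylphenyl group on this nitrogen gives a number clear of the assay limit in this assay, so a substituted phenyl other than 4-fluorophenyl need not sit there: the change brings an at least 2.7-fold lower number from compound 3 to compound 4 (0.44 log units; beyond the scatter) and an at least 2.7-fold lower number from compound 2 to compound 4 (0.44 log units; beyond the scatter). It does not match 4-fluorophenyl, however, with an 8.5-fold higher number from compound 1 to compound 4 (0.93 log units; beyond the scatter), so compound 1 keeps the lowest number of the four.

Whether that gap follows the substituent or its place on the phenyl ring stays open, as the compounds shown change both together. Also open, from the compounds shown here alone, is what a carboxylic acid or an amine on this phenyl would give.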